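A Chloro-to-Fluoro Swap on the Benzyl Ring

This account rests on a few compounds, and the source may have more. Where it says the series, first, only, none or still open, it means among the compounds named here.

Compound 1 `O=C(O)CCc1ccc(NC(=O)c2nnc(COc3ccc(F)cc3)s2)cc1` and compound 2 `O=C(O)CCc1ccc(NC(=O)c2nnc(Cc3cccc(Cl)c3)s2)cc1` share one core. In a functional assay on CHO cells for agonist activity at Free fatty acid receptor 1 (Homo sapiens), read by FLIPR and calcium flux, tested at 1 uM (on this read-out higher numbers stand for an effect only at larger amounts of compound and lower numbers for an effect already at smaller amounts), compound 1 gives 5390 nM, and compound 2 gives 2390 nM. For the measured compounds named here, the single measured step, a 2.3-fold lower number from compound 1 to compound 2 (0.35 log units; beyond the scatter), came with 3-chlorophenyl in place of 4-fluorophenoxy. Going by the values given here, compound 2 thus holds the lowest of the two numbers at hand, the only other being compound 1. Compound 3 `O=C(O)CCc1ccc(NC(=O)c2nnc(Cc3cccc(F)c3)s2)cc1` is the next member. Its change from compound 2 reads: fluoro in place of chloro on an aromatic carbon; cut one bond further out, 3-chlorobenzyl becomes 3-fluorobenzyl. Among the compounds with values here, no measured step exchanges one halogen for another on this ring, so the step from compound 1 to compound 2 bears on it only loosely, as a sign that this end of the molecule moves the number. The step is expected to be small, a 1.5-fold higher number from compound 2 to compound 3 (0.17 log units; within the scatter), likely within the scatter. Compound 3 is therefore estimated at 3500 nM, with a range from 1500 nM to 8000 nM.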

Compound 3, half-maximal effective concentration: 5020 nM
The estimate for compound 3 lay 1.4-fold (0.16 log units) below the measured number; low and high end bracket the measured number.
By their numbers in this assay, from the lowest: compound 2; then compounds 3 and 1 (each within the scatter of the next).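

In this assay, fluoro in place of chloro on an aromatic carbon brought a 2.1-fold higher number from compound 2 to compound 3 (0.32 log units; beyond the scatter), so exchanging one halogen atom for another on this ring, with no change in the counts of rings, donors, acceptors or charge, is enough to move the number. The other new step, a 1.1-fold lower number from compound 1 to compound 3 (0.03 log units; within the scatter), does not separate the 3-fluorobenzyl end from the end bearing 4-fluorophenoxy, which leaves compound 2, the chloro member, as the only one of the three standing apart from both others. No measurement given here explains why chloro and fluoro differ at this place.

From the compounds shown here alone, whether bromo, methyl or trifluoromethyl on this ring would give a number like that of compound 2 or that of compound 3 stays open. So does whether the chloro-to-fluoro step would hold on a 4-chlorophenoxy end.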